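This account rests on a few compounds, and the source may have more. Where it says the series, first, only, none or still open, it means among the compounds named here.

Of the compounds shown here, two sharing one core have been measured. Compound 1 `O=C(Nc1cccc(-n2cc(-c3ccncc3)c(-c3cc(O)cc(Cl)c3)n2)c1)Nc1ccc(Cl)c(Cl)c1` in a functional assay on HOP-62 cells (Homo sapiens) for inhibition, read by sulforhodamine B assay, with a stated time of 48 h, tested at 0.1 uM (on this read-out lower numbers stand for a stronger effect and higher numbers for a weaker effect at the one concentration tested), gives 97%. Compound 2 `COc1cc(Cl)cc(-c2nn(-c3cccc(NC(=O)Nc4cc(C(F)(F)F)cc(C(F)(F)F)c4)c3)cc2-c2ccncc2)c1` in this assay gives 93%, the lower of the two numbers, though the gap to compound 1 lies within the usual scatter, so the two compounds cannot be set apart on this read-out.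

Compound 3 `COc1cc(Cl)cc(-c2nn(-c3cccc(NC(=O)Nc4cccc(C(F)(F)F)c4)c3)cc2-c2ccncc2)c1` differs from compound 2 in one place: hydrogen in place of trifluoromethyl on an aromatic carbon. Going by the values given here, no step between measured compounds is known here, so there is no measured guide to how much a change of this kind moves the read-out. Both measured numbers sit near the top of the scale, and a single trifluoromethyl removed from the shared core is expected to move the number from compound 2 to compound 3 by a number 2 percentage points higher from compound 2 to compound 3 (within the scatter), a step not expected to exceed the scatter. Compound 3 is therefore expected to give about 95% in this assay, in a range from 82% to 106%.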

Compound 3, a percentage reported as activity, at one concentration (the size of the read-out at that concentration, not a potency): 97%
Estimate against measurement, compound 3: 2 percentage points below; low and high end bracket the measured number.
By their numbers in this assay, from the lowest: compounds 2, 1 and 3 (each within the scatter of the next).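

In this assay, hydrogen in place of trifluoromethyl on an aromatic carbon gives a number 4 percentage points higher from compound 2 to compound 3 (within the scatter) and this is the only measured step among the compounds shown. At this place, meta to a large group and meta to a trifluoromethyl group, the read-out at the one concentration tested therefore does not set compound 2 and compound 3 apart, although the change takes away 4 heavy atoms. No measurement shown bears on why the step has this size.

The compounds shown leave open whether another group at this place, such as an amine, a carboxylic acid or a longer chain, would give a step beyond the scatter. They also leave open what replacing the remaining trifluoromethyl with hydrogen would do to the read-out.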